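A few compounds are considered here, and "the series" means these few. Any claim that something is new, unique, unknown or untested is made for them only; others in the source may bear on it.

In a physicochemical assay for solubility, read by HPLC, in phosphate buffer, measured as kinetic solubility, at pH 7.4 (a lower number here means a less soluble compound, a higher number a more soluble compound), compound 1 (`NS(=O)(=O)c1ccc(-c2cc(C(=O)CC3CCC3)nn2-c2ccc(Cl)cc2)cc1`) gives 4300 nM and compound 2 (`NS(=O)(=O)c1ccc(-c2cc(C(=O)CC3CCCC3)nn2-c2ccc(Cl)cc2)cc1`) gives 2600 nM in the same test, and the step joining them is a 1.7-fold lower number from compound 1 to compound 2 (0.22 log units; within the scatter) on this scale. Compound 3 (`NS(=O)(=O)c1ccc(-c2cc(C(=O)N3CC4CC4C3)nn2-c2ccc(Cl)cc2)cc1`) stands highest of the three at 36600 nM in this small set. It is reached by an 8.5-fold higher number from compound 1 to compound 3 (0.93 log units; beyond the scatter) and by a 14-fold higher number from compound 2 to compound 3 (1.15 log units; beyond the scatter) in the two measured comparisons. Compound 4 (`NS(=O)(=O)c1ccc(-c2cc(C(=O)N3CCCCC3)nn2-c2ccc(Cl)cc2)cc1`) carries piperidin-1-yl on a carbonyl carbon, and the change is a group of 6 heavy atoms (5 carbon, 1 nitrogen; one six-membered non-aromatic ring with 1 hetero atom) in place of a group of 6 heavy atoms (5 carbon, 1 nitrogen; one three-membered non-aromatic ring of carbon only, one five-membered non-aromatic ring with 1 hetero atom), on a carbonyl carbon at that place. Both steps into compound 3 put a nitrogen-bearing group on the carbonyl carbon, and compound 4 keeps such a group there, so neither step is expected to repeat. No two nitrogen-bearing groups have yet been compared directly. The closest guide is a change between two carbon rings, a 1.7-fold lower number from compound 1 to compound 2 (0.22 log units; within the scatter) in size. Only a small fall is therefore expected, probably not beyond the scatter, and the estimated step is a 1.7-fold lower number from compound 3 to compound 4 (0.22 log units; within the scatter) in this assay here. The estimate for compound 4 is 22000 nM as a middle value. The expected range for compound 4 runs from 8000 nM to 50000 nM in this test.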

Compound 4, solubility: 65900 nM
Estimate against measurement, compound 4: 3.0-fold (0.48 log units) below; measured number above the stated range.
By their numbers in this assay, from the lowest: compounds 2 and 1 (each within the scatter of the next); then compounds 3 and 4 (each within the scatter of the next).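

In this assay, two groups joined through a ring nitrogen to the carbonyl carbon can now be compared directly, and the step is a 1.8-fold higher number from compound 3 to compound 4 (0.26 log units; within the scatter), so piperidin-1-yl and the group it replaces do not separate. Against the carbon-linked groups, piperidin-1-yl gives a 25-fold higher number from compound 2 to compound 4 (1.40 log units; beyond the scatter) and a 15-fold higher number from compound 1 to compound 4 (1.19 log units; beyond the scatter), so among these four compounds, compound 3 and compound 4 both lie beyond the scatter from compound 1 and compound 2, and none goes against this split. Nothing available here bears on the cause of these results.

The compounds shown leave open whether morpholin-4-yl, with a ring oxygen added, or an open-chain diethylamino group on the carbonyl carbon would fall with compound 3 and compound 4. They also leave open whether the split holds for a smaller ring such as pyrrolidin-1-yl.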